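The source may report more compounds than this note shows. Statements on the series, on what has been measured and on what is new or still open speak of the compounds shown alone.

Measured compounds:
- compound 1, `O=C(CSc1nc2ccccc2[nH]1)Nc1ccc2nc(NC(=O)c3ccc(C(F)(F)F)cc3)sc2c1`: 7110 nM
- compound 2, `COc1cc(CNC(C)(C)CO)ccc1OCC(=O)Nc1ccc(C)cc1`: > 100000 nM
- compound 3, `O=C(CSc1cccc(O)c1)Nc1ccc2nc(NC(=O)c3ccc4ccccc4c3)sc2c1`: 1770 nM

All three were tested in a functional assay on U2OS cells (Homo sapiens) for antiproliferative activity, read by MTT assay, with a stated time of 72 h; a lower number here means a stronger inhibitor, a higher number a weaker inhibitor. Of the two results that are numbers, compound 1 gives the highest with 7110 nM, while compound 3 gives 1770 nM, a gap that lies beyond the usual scatter. The result for compound 2 is a limit of the assay and not a number; compound 2 sits at the limit of > 100000 nM in this assay, at which 1 of the 3 values shown sits.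

The next compound, compound 4 `O=C(CSc1ccc(Cl)cc1)Nc1ccc2nc(NC(=O)c3ccc(C(F)(F)F)cc3)sc2c1`, keeps the shared core of compound 1 and changes only the group carried by the sulfur: 4-chlorophenyl in place of 1H-benzimidazol-2-yl on a sulfur. Going by the values given here, no pair of measured compounds differs in a single place, so there is no measured step from which to read the size of this change. The closest hint is compound 3, which also carries a six-membered carbon ring on that sulfur, though with a different amide, and gives 1770 nM in this assay. On that basis the step from compound 1 to compound 4 is expected to be a moderate move toward a lower number, a 2.4-fold lower number from compound 1 to compound 4 (0.37 log units; beyond the scatter). Compound 4 is therefore estimated at 3000 nM, with a likely range from 900 nM to 10000 nM.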

Compound 4, half-maximal inhibitory concentration: 2890 nM
Beside the measured number, compound 4's estimate is 1.0-fold (0.02 log units) above it, and the stated range covers the measured number.
By their numbers in this assay, from the lowest: compounds 3 and 4 (each within the scatter of the next); then compound 1. At a limit, above all of these: compound 2.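

Going by these compounds alone, this is the first step that can be read cleanly: with the shared core and the rest of the molecule held fixed, swapping the group on the sulfur gives a 2.5-fold lower number from compound 1 to compound 4 (0.39 log units; beyond the scatter) in this assay. The group carried by this sulfur therefore affects the antiproliferative number, though the size of the step is modest. The 1H-benzimidazol-2-yl group, with its hydrogen-bond donor and acceptor, is also not required for activity in this range, since 4-chlorophenyl, which has neither, gives the lower number, but nothing among the data shown accounts for why the number moves in this direction.

From the compounds shown here alone, with only one replacement on this sulfur to go on, it remains open whether the chlorine matters or the ring alone is enough, and what an unsubstituted phenyl, a 4-methoxyphenyl or a saturated cyclohexyl would give with the same amide. Compound 3 differs from compound 4 in more than one place, so the two cannot be compared as a step, and the separate contribution of the amide group remains unresolved.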